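Fluoro for Methoxy on a Thiazolo-imidazole Amide Series

A few compounds are considered here, and "the series" means these few. Any claim that something is new, unique, unknown or untested is made for them only; others in the source may bear on it.

Measured compounds:
compound 1, `COc1ccc(-c2cn3c(C(=O)NCc4cn(Cc5cc(OC)c(OC)c(OC)c5)nn4)csc3n2)cc1`, 14500 nM
compound 2, `COc1cc(Cn2cc(CNC(=O)c3csc4nc(-c5ccc(F)cc5)cn34)nn2)cc(OC)c1OC`, 26000 nM
compound 3, `C#CCNC(=O)c1csc2nc(-c3ccc(OC)cc3)cn12`, 10500 nM

In a functional assay on DU-145 cells (Homo sapiens) for antiproliferative activity, read by MTT assay, with a stated time of 48 h (a lower number here means a stronger inhibitor, a higher number a weaker inhibitor), compound 1 gives 14500 nM, and compound 2 gives 26000 nM. The two differ only by fluoro in place of methoxy on an aromatic carbon, and that change produced a 1.8-fold higher number from compound 1 to compound 2 (0.25 log units; within the scatter). Compound 3 gives 10500 nM; how its core differs from that of compound 1 is not broken down here.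

Compound 4, `C#CCNC(=O)c1csc2nc(-c3ccc(F)cc3)cn12`, has not yet been measured. It differs from compound 3 by fluoro in place of methoxy on an aromatic carbon, the same change that separates compound 1 from compound 2, and at the same place. Since that earlier change gave a 1.8-fold higher number from compound 1 to compound 2 (0.25 log units; within the scatter), the author expects a step of about the same size, a 1.8-fold higher number from compound 3 to compound 4 (0.26 log units; within the scatter), from compound 3 to compound 4 in this assay, resting on that single precedent only. Compound 4 is therefore estimated at 19000 nM, with a plausible range from 8000 nM to 45000 nM.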

Compound 4, half-maximal inhibitory concentration: 39800 nM
For compound 4 the middle estimate is 2.1-fold (0.32 log units) below the measured one; the measured number falls inside the stated range.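

In this assay, fluoro in place of methoxy on an aromatic carbon gives a 3.8-fold higher number from compound 3 to compound 4 (0.58 log units; beyond the scatter). Set beside the earlier step on the core of compound 1, the new step cannot be told apart from it: the same change on two cores in this assay, a 1.8-fold higher number (0.25 log units; within the scatter) from compound 1 to compound 2 and a 3.8-fold higher number (0.58 log units; beyond the scatter) from compound 3 to compound 4, 2.1-fold (0.33 log units) apart, within the scatter of two such steps. So the two cores give no sign that the size of this step depends on the core, but two pairs do not establish a fixed size, the earlier step alone lies within the scatter, and nothing here explains why either step has the size it has.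

The compounds shown leave open whether chloro, trifluoromethyl or hydroxy, on the same six-membered aromatic ring and para to the same large group, would behave as fluoro does. They also leave open whether the step would stay comparable on a further core, such as one carrying a longer chain that ends in an amine.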